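Halogen back in place of methoxy on the amine nitrogen

A few compounds are considered here, and "the series" means these few. Any claim that something is new, unique, unknown or untested is made for them only; others in the source may bear on it.

Measured so far in a functional assay on A-431 cells (Homo sapiens) for antiproliferative activity, read by MTT assay, with a stated time of 72 h; a higher number here means a weaker inhibitor, a lower number a stronger inhibitor:
Compound 1 `COc1cc2ncnc(Nc3ccc(Br)cc3)c2cc1OCCCCC(=O)Nc1ccc(S(N)(=O)=O)cc1` gives 6570 nM.
Compound 2 `COc1ccc(Nc2ncnc3cc(OC)c(OCCCCC(=O)Nc4ccc(S(N)(=O)=O)cc4)cc23)cc1` gives 14700 nM.

Among the compounds with values here, compound 2 shows the higher of the two numbers, and compound 1 is its only neighbour. Compound 3 `COc1cc2ncnc(Nc3ccc(F)c(Br)c3)c2cc1OCCCCC(=O)Nc1ccc(S(N)(=O)=O)cc1` differs from compound 2 by 3-bromo-4-fluorophenyl in place of 4-methoxyphenyl on a nitrogen on an aromatic ring. Within the data shown here, the one measured step that bears on this is a 2.2-fold higher number from compound 1 to compound 2 (0.35 log units; beyond the scatter), where methoxy replacing bromo raised the number; compound 3 brings bromo back, now joined by fluorine. A step of similar size in the opposite direction is therefore expected in this assay, namely a 2.9-fold lower number from compound 2 to compound 3 (0.47 log units; beyond the scatter). For compound 3 the estimated value is 5000 nM, within 1500 nM to 15000 nM.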

Compound 3, half-maximal inhibitory concentration: 8020 nM
The estimate for compound 3 lay 1.6-fold (0.21 log units) below the measured number; the range from low to high includes it.
By their numbers in this assay, from the lowest: compounds 1, 3 and 2 (each within the scatter of the next, the first and the last beyond it).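

In this assay the change on this nitrogen from 4-methoxyphenyl to 3-bromo-4-fluorophenyl gives a 1.8-fold lower number from compound 2 to compound 3 (0.26 log units; within the scatter) and the change from 4-bromophenyl to 3-bromo-4-fluorophenyl gives a 1.2-fold higher number from compound 1 to compound 3 (0.09 log units; within the scatter). Compound 3 therefore cannot be separated from either neighbour, even though compound 1 and compound 2 lie beyond the scatter of each other. Nothing available explains these numbers.

Still open, from the compounds shown here alone, is how a plain phenyl or a 3-chloro-4-fluorophenyl would read on this nitrogen, and whether a shorter chain would alter the picture.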